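The source may hold more compounds than are shown below. What is called first, only, known or untested is meant among the compounds shown, and "the series" means these compounds.

Measured so far:
- compound 1 `Cc1ccccc1/C(CCN1CCN(c2ccccn2)CC1)=N/O` gives 4.2 nM in a functional assay on HEK293 cells with D(4) dopamine receptor (Homo sapiens) as the target, read by FLIPR; on this read-out higher numbers stand for an effect only at larger amounts of compound and lower numbers for an effect already at smaller amounts
- compound 2 `O/N=C(\CCN1CCN(c2ccccn2)CC1)c1ccc(F)cc1` gives 31 nM in this assay

Compound 2 holds the higher of these two numbers, and the step of a 7.4-fold higher number from compound 1 to compound 2 (0.87 log units; beyond the scatter) lies beyond the scatter, so the two compounds are genuinely set apart. Compound 3 `O/N=C(\CCN1CCN(c2ccccn2)CC1)c1ccc(Cl)cc1` has not yet been measured. It differs from compound 2 in a single place: chloro in place of fluoro on an aromatic carbon. Among the measured compounds shown here, the one measured step, a 7.4-fold higher number from compound 1 to compound 2 (0.87 log units; beyond the scatter), exchanges the whole aryl group and therefore bears only loosely on a swap of one halogen for another on the same ring; no measured pair sets fluoro directly against chloro. Without such a comparison, the step of a 1.0-fold lower number from compound 2 to compound 3 (0.01 log units; within the scatter) is expected to stay within the scatter, with no clear direction. The value of compound 3 in this assay is therefore estimated at 30 nM, within a range from 10 nM to 90 nM.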

Compound 3, half-maximal effective concentration: 475 nM
The estimate for compound 3 lay 16-fold (1.20 log units) below the measured number, outside the stated range (above it).
By their numbers in this assay, from the lowest: compound 1; then compound 2; then compound 3.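

In this assay, the exchange of one halogen atom on the aromatic ring is no small edit: chloro in place of fluoro gives a 15-fold higher number from compound 2 to compound 3 (1.19 log units; beyond the scatter), a large step from a change of a single heavy atom. Measured against the 2-methylphenyl group, the 4-chlorophenyl group gives a 110-fold higher number from compound 1 to compound 3 (2.05 log units; beyond the scatter), so this position, para to a large group, clearly tolerates some groups far better than others in this small set. Nothing available gives a reason for this difference between fluoro and chloro.

The compounds shown leave open whether a bromo or a methoxy group at this place would behave more like fluoro or more like chloro. They also leave open where a plain phenyl ring, with only hydrogen at this place, would fall relative to compound 2 and compound 3.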